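The compounds below may be only part of what the source reports. "The series", "measured", "known", "first", "only" and "open" are said of these compounds alone.

Measured in an assay on CHO cells for displacement of a labelled ligand from adenosine receptor A1 (Homo sapiens); a higher number here means a weaker inhibitor, a lower number a stronger inhibitor:
Compound 1 `COc1ccc(CNc2ncc(C(=O)O)c3nc(-c4ccco4)nn23)cc1` gives 5760 nM.
Compound 2 `O=C(O)c1cnc(NCc2ccc(Cl)cc2)n2nc(-c3ccco3)nc12` gives only a limit of the assay, > 100000 nM.

Compound 2 therefore stands at the limit of > 100000 nM in this assay, at which 1 of the 2 values shown sits. Going by the values given here, the only measured step is the exchange of methoxy for chloro, an at least 17-fold higher number from compound 1 to compound 2 (1.23 log units; beyond the scatter). Compound 3 `O=C(O)c1cnc(NCc2ccc(C(F)(F)F)cc2)n2nc(-c3ccco3)nc12` differs from compound 2 by trifluoromethyl in place of chloro on an aromatic carbon. Among the compounds with values here, no measured step matches this change; the one step at this position was large, but the value of compound 2 is a limit, so no direction for compound 3 can be read from it. Compound 3 is expected to remain near that limit, at 100000 nM (from 30000 nM to 300000 nM). That estimate means a number no higher from compound 2 to compound 3 (the limit leaves the size open) in this assay .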

Compound 3, inhibition constant: > 100000 nM
Compound 3 ended at the assay's limit; the forecaster's own chance of this, stated with the estimate: 60%; the middle value lies on the limit itself.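

In this assay, replacing methoxy with trifluoromethyl at this place gives an at least 17-fold higher number from compound 1 to compound 3 (1.23 log units; beyond the scatter), so chloro is no longer the only replacement of methoxy that yields no measurable number. The step between chloro and trifluoromethyl cannot be read, since both values are limits. Only compound 1 now keeps a measured number, and the other two share the limit: the limit of > 100000 nM in this assay, at which 2 of the 3 values shown sit.

From the compounds shown here alone, whether an amine, a hydroxyl or an ethoxy group at this place would give a measurable number stays open.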